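This account rests on a few compounds, and the source may have more. Where it says the series, first, only, none or still open, it means among the compounds named here.

Measured in a functional assay on A-427 cells (Homo sapiens) for cytotoxicity, read by colorimetric assay and MTT assay; on this read-out higher numbers stand for weaker inhibition and lower numbers for stronger inhibition:
Compound 1 `COc1cc(OC)c2cc(-c3ccc(OCc4ccccc4)cc3)c(O)nc2c1` gives 10000 nM
Compound 2 `CCN(CC)C(=O)Cn1c(=O)c(-c2ccc(OC)cc2)cc2c(OC)cc(OC)cc21` gives 10000 nM

Compound 2 stands level with compound 1 on these numbers, the two values lying within the usual scatter of each other. The next compound, compound 3 `COc1ccc(-c2cc3c(OC)cc(OC)cc3n(CCC(=O)OCc3ccccc3)c2=O)cc1`, has not yet been measured. It departs from compound 2 in one place: (benzyloxycarbonyl)methyl in place of diethylcarbamoyl on a saturated chain carbon bound to an aromatic nitrogen. Going by the values given here, no two measured compounds differ in only one place, so the data give no direct guide to the size of such a change. In this assay no step beyond the scatter is expected, in either direction. That expectation starts from compound 2 at 10000 nM. The estimated change is small, a 1.1-fold lower number from compound 2 to compound 3 (0.05 log units; within the scatter). Compound 3 is expected at 9000 nM, with an estimated range from 3000 nM to 25000 nM.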

Compound 3, half-maximal inhibitory concentration: 10000 nM
The estimate for compound 3 lay 1.1-fold (0.05 log units) below the measured number, within the range that was stated.
By their numbers in this assay, from the lowest: compounds 1, 2 and 3 (each within the scatter of the next).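

In this assay, placing (benzyloxycarbonyl)methyl in place of diethylcarbamoyl on a saturated chain carbon bound to an aromatic nitrogen gives no change at the digits printed from compound 2 to compound 3 (within the scatter) and thus provides the first reading of a single change among these compounds. It shows that, on this read-out, the number stays put at this position when a group with no ring gives way to one carrying a six-membered aromatic ring of carbon only. Nothing available here accounts for this outcome.

The compounds shown leave open whether any other group at this position would separate from the number shared by compound 2 and compound 3. As far as these compounds go, a carboxylic acid or an amine on this chain, for example, remains untested among them, so how far the position tolerates change is still unknown.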